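Shifting the Amino Group: From Compound 3 to Compound 4

The source may hold more compounds than are shown below. What is called first, only, known or untested is meant among the compounds shown, and "the series" means these compounds.

Compound 1 `CCN1C(=O)S/C(=C\c2ccc(N)cc2)C1=O`: 76000 nM
Compound 2 `Nc1cccc(/C=C2\SC(=O)N(Cc3ccc(F)cc3)C2=O)c1`: 140000 nM
Compound 3 `Nc1cccc(/C=C2\SC(=O)N(Cc3cccc(Cl)c3)C2=O)c1`: 164000 nM

In a functional assay on FM3A cells (Mus musculus) for cytotoxicity, read by cell counting, with a stated time of 2 days (on this read-out higher numbers stand for weaker inhibition and lower numbers for stronger inhibition), compound 3 sits among the high numbers, with compound 2 within the scatter of it and compound 1 a lower number beyond the scatter. Compound 4 `Nc1ccc(/C=C2\SC(=O)N(Cc3cccc(Cl)c3)C2=O)cc1` is not yet measured and differs from compound 3 by 4-aminophenyl in place of 3-aminophenyl on a double-bonded chain carbon bound to a double-bonded ring carbon. Going by the values given here, no measured step changes this group on its own: the only measured step, a 1.2-fold higher number from compound 2 to compound 3 (0.07 log units; within the scatter), concerns a different place and is within the scatter. Compound 1 also carries 4-aminophenyl but differs from compound 4 elsewhere as well, so its lower number is only a loose hint. A modest move to a lower number is therefore expected for compound 4, a 1.5-fold lower number from compound 3 to compound 4 (0.17 log units; within the scatter), giving an estimate of 110000 nM with a range from 45000 nM to 270000 nM.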

Compound 4, half-maximal inhibitory concentration: 10000 nM
Compound 4: the middle estimate sits 11-fold (1.04 log units) above what was measured, and the stated range ends above it.
By their numbers in this assay, from the lowest: compound 4; then compounds 1, 2 and 3 (each within the scatter of the next, the first and the last beyond it).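

In this assay, moving the amino group alone, with the same atoms joined differently, gives a 16-fold lower number from compound 3 to compound 4 (1.21 log units; beyond the scatter) and so shows that this position matters far more than the earlier step at a different place suggested. With 4-aminophenyl kept, 3-chlorophenyl in place of methyl gives a 7.6-fold lower number from compound 1 to compound 4 (0.88 log units; beyond the scatter) and so shows that the group on the ring nitrogen's chain carbon also counts. Nothing measured here explains either step. As far as these compounds go, whether a hydroxyl or a dimethylamino group in place of the amino group would keep so low a number stays open, as does how the 4-fluorophenyl of compound 2 behaves alongside 4-aminophenyl.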